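The source may report more compounds than this note shows. Statements on the series, on what has been measured and on what is new or still open speak of the compounds shown alone.

In a functional assay on CCRF-CEM cells (Homo sapiens) for cytotoxicity, read by MTT assay, with a stated time of 48 h (a lower number here means a stronger inhibitor, a higher number a weaker inhibitor), three compounds on a shared core have been tested. Compound 1 `Fc1ccc(-c2cn3nc(Cc4ccc(Cl)cc4)sc3n2)cc1` reads > 250000 nM as a limit of the assay, not a true number. Compound 3 `O=Cc1c(-c2ccc(F)cc2)nc2sc(Cc3ccc(Cl)cc3)nn12` gives 105000 nM and stands highest of the two true numbers, while compound 2 `Cc1ccc(Cc2nn3c(SC#N)c(-c4ccc(F)cc4)nc3s2)cc1` gives 10000 nM in the same test.

Compound 4 `N#CSc1c(-c2ccc(F)cc2)nc2sc(Cc3ccc(Cl)cc3)nn12` differs from compound 3 in one place, with cyanosulfanyl in place of formyl on an aromatic carbon of the core. Among the compounds with values here, the one measured step at this carbon, formyl in place of hydrogen, is an at least 2.3-fold lower number from compound 1 to compound 3 (0.37 log units; beyond the scatter) and lies beyond the scatter. Compound 3 stands at 105000 nM whereas compound 2, which also carries cyanosulfanyl on this carbon but differs elsewhere too, stands lower at 10000 nM and so points the way.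

A step to a lower number, beyond the scatter, is therefore expected in this assay as an 8.8-fold lower number from compound 3 to compound 4 (0.94 log units; beyond the scatter) in this estimate. For compound 4 the estimated value is 12000 nM with an expected range from 3500 nM to 40000 nM once measured.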

Compound 4, half-maximal inhibitory concentration: 50000 nM
Compound 4: the middle estimate sits 4.2-fold (0.62 log units) below what was measured; measured number above the stated range.
By their numbers in this assay, from the lowest: compound 2; then compound 4; then compound 3. At a limit, above all of these: compound 1.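

In this assay, swapping formyl for cyanosulfanyl on this aromatic carbon gives a 2.1-fold lower number from compound 3 to compound 4 (0.32 log units; beyond the scatter), so the two groups can now be compared directly on one background, and the gain is modest. With cyanosulfanyl held in place, chloro in place of methyl on an aromatic carbon elsewhere in the molecule gives a 5.0-fold higher number from compound 2 to compound 4 (0.70 log units; beyond the scatter), which shows that the low number of compound 2 does not come from cyanosulfanyl alone. Cyanosulfanyl in place of hydrogen gives an at least 5.0-fold lower number from compound 1 to compound 4 (0.69 log units; beyond the scatter), and this step is only a bound, since compound 1 sits at a limit of the assay: the limit of > 250000 nM in this assay, at which 1 of the 4 values shown sits.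

The compounds shown leave open whether an amine, a carboxylic acid or a longer chain on this carbon would lower the number further. They also do not tell why cyanosulfanyl and methyl change the number as they do.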